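A few compounds are considered here, and "the series" means these few. Any claim that something is new, unique, unknown or untested is made for them only; others in the source may bear on it.

Measured compounds in a functional assay on B16 cells (Mus musculus) for cytotoxicity, read by MTT assay, with a stated time of 48 h; on this read-out higher numbers stand for weaker inhibition and lower numbers for stronger inhibition:

- compound 1, `CC1(C)CCC[C@]1(C)c1ccc(C=O)cc1`: compound 1 gives 257000 nM
- compound 2, `C#CC1=CC[C@@]2(C)C(=C)CCC[C@]2(C)CC1`: compound 2 gives 507000 nM
- compound 3, `C=C1CCC[C@]2(C)CCC(c3cn(-c4ccc(OC)cc4)nn3)=CC[C@@]12C`: compound 3 gives 209000 nM

All three numbers sit in a weak range on this assay. Compound 3 and compound 1 lie within the scatter of each other, so no order between them can be read. Compound 2 stands apart: its number is higher than that of compound 3 by a gap beyond the scatter, which is the only separation in the set that can be trusted. For the measured compounds named here, no pair of the measured compounds differs in a single place, so no step within the measured set can be stated.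

Compound 4, `C=C1CCC[C@]2(C)CCC(c3cn(-c4cccc(OC)c4)nn3)=CC[C@@]12C`, is not yet measured. It differs from compound 3 as follows: 3-methoxyphenyl in place of 4-methoxyphenyl on an aromatic nitrogen. The two compounds share every atom, joined differently; only where the methoxy sits on the aromatic ring changes. With no measured step of this kind in the set, the expectation rests on the closeness of the two structures alone. The step of a 1.0-fold higher number from compound 3 to compound 4 (0.00 log units; within the scatter) is expected to stay within the scatter, in no particular direction. For compound 4 the estimate in this assay is 210000 nM, with a range from 100000 nM to 450000 nM.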

Compound 4, half-maximal inhibitory concentration: 34700 nM
Compound 4: the middle estimate sits 6.1-fold (0.78 log units) above what was measured, and the stated range ends above it.
By their numbers in this assay, from the lowest: compound 4; then compounds 3, 1 and 2 (each within the scatter of the next, the first and the last beyond it).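

For the compounds shown here, exchanging 4-methoxyphenyl for 3-methoxyphenyl on the aromatic nitrogen of the five-membered ring gives a 6.0-fold lower number from compound 3 to compound 4 (0.78 log units; beyond the scatter) in this assay and is the first single-place step, with a size beyond the scatter. The groups that leave and enter have the same heavy atoms, the same hydrogen-bond donor and acceptor counts and no net charge, so this read-out is sensitive to where the methoxy sits on the aromatic ring, even with the atoms unchanged. Nothing at hand accounts for this sensitivity.

The compounds shown leave open whether the lower number of compound 4 depends on the methoxy itself or would also appear with another group at the same place on the ring, such as an ethoxy, an amine or a carboxylic acid. Going by these compounds alone, they also leave open whether the step holds on cells other than the single line tested here, or on a shared core other than the one that compound 3 and compound 4 carry.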